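Bromo for Fluoro on the Benzyl Ring: Expectation for Compound 4

The source may report more compounds than this note shows. Statements on the series, on what has been measured and on what is new or still open speak of the compounds shown alone.

Measured so far:
compound 1 `O=C(C1CCCN(Cc2ccccc2)C1)N1CCN(c2ccccc2Cl)CC1` gives 22%
compound 2 `O=C(C1CCCN(Cc2ccccc2F)C1)N1CCN(c2ccccc2Cl)CC1` gives 50%
compound 3 `O=C(C1CCCN(Cc2ccc(F)cc2)C1)N1CCN(c2ccccc2Cl)CC1` gives 40%

All three were tested in a functional assay on a cell-free system (Platelet, plasma, Homo sapiens), with stated times of 4 min and 5.5 min, tested at 1 uM; a higher number here means a weaker effect of the compound at the concentration tested, a lower number a stronger effect. Compound 3 stands second highest of the three numbers in this assay: its nearest neighbour is compound 2, with a number 10 percentage points lower from compound 2 to compound 3 (within the scatter), a gap inside the usual scatter, so the two cannot be ranked against each other; its furthest is compound 1, with a number 18 percentage points higher from compound 1 to compound 3 (beyond the scatter).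

Compound 4 `O=C(C1CCCN(Cc2ccc(Br)cc2)C1)N1CCN(c2ccccc2Cl)CC1` has not yet been measured. It differs from compound 3 in one place: bromo in place of fluoro on an aromatic carbon.

Among the compounds with values here, none of the measured steps swaps one halogen for another. The two that come closest both put fluoro in place of hydrogen on the same benzyl ring: a number 28 percentage points higher from compound 1 to compound 2 (beyond the scatter) and a number 18 percentage points higher from compound 1 to compound 3 (beyond the scatter), each a modest rise, meaning a weaker effect. A change from fluoro to bromo at the same position is a smaller kind of change than adding a halogen where none was, so a step of at most similar size, in either direction, is expected, and most likely one that stays within the scatter.

For compound 4 the expected step is a number 5 percentage points higher from compound 3 to compound 4 (within the scatter), giving an estimated 45% with a range from 25% to 65%.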

Compound 4, a percentage reported as activity, at one concentration (the size of the read-out at that concentration, not a potency): 39%
Compound 4: middle estimate off by 6 percentage points, on the high side; the range from low to high includes it.
By their numbers in this assay, from the lowest: compound 1; then compounds 4, 3 and 2 (each within the scatter of the next, the first and the last beyond it).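

In this assay, changing 4-fluorobenzyl to 4-bromobenzyl gives a number 1 percentage points lower from compound 3 to compound 4 (within the scatter) and so leaves no readable difference, which means that fluoro and bromo cannot be told apart at this place on the ring. The rise first seen with fluoro also appears with a different halogen, at a number 17 percentage points higher from compound 1 to compound 4 (beyond the scatter) here, so among the compounds shown the weaker effect relative to the unsubstituted benzyl of compound 1 is not unique to fluoro. The remaining comparison, a number 11 percentage points lower from compound 2 to compound 4 (beyond the scatter) in this case, only just clears the scatter and changes both the halogen and its place on the ring, so it cannot show which of the two changes matters.

From the compounds shown here alone, whether a group of a different kind at this place, such as methoxy or an amine, would sit with the halogens or with the unsubstituted compound 1 remains open, as does whether 2-bromophenyl would read like 2-fluorophenyl. Nothing available here explains why the two halogens read alike or why either differs from hydrogen.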